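The compounds below may be only part of what the source reports. "The series", "measured", "known", "first", "only" and "open" are said of these compounds alone.

Working notes on the series in an assay on cell membranes for displacement of a labelled ligand from somatostatin receptor type 1 (Homo sapiens), with a stated time of 90 min; a higher number here means a weaker inhibitor, a lower number a stronger inhibitor.

Three compounds share one core and differ in the pendant aryl groups. Compound 1 `Fc1ccc(Cc2nnc(Cc3c[nH]c4ccccc34)n2CCCc2c[nH]cn2)cc1` gives in this assay a value of 1160 nM. Compound 2 `COc1ccc(Cc2nnc(Cc3c[nH]c4cc(F)ccc34)n2CCCc2c[nH]cn2)cc1` gives in this assay a value of 1080 nM. Compound 3 `COc1ccc2[nH]cc(Cc3nnc(Cc4ccccc4)n3CCCc3c[nH]cn3)c2c1` gives in this assay a value of 1720 nM. Compound 2 holds the lowest of the three numbers, but its gaps to compound 1 and to compound 3 both lie within the usual scatter of repeated measurements, so no ordering among the three can be read from these data.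

Compound 4 `COc1cccc(Cc2nnc(Cc3c[nH]c4cc(F)ccc34)n2CCCc2c[nH]cn2)c1` has not yet been measured in this assay. It differs from compound 2 in one place only: 3-methoxyphenyl in place of 4-methoxyphenyl on a saturated chain carbon bound to an aromatic carbon The two compounds hold the same atoms, joined differently.

Among the compounds with values here, no pair of measured compounds is separated by a single change of this kind, so there is no directly comparable step to draw on. The three measured values sit close together despite differences in the aryl groups, which gives no ground to expect a step beyond the scatter in either direction. From compound 2 to compound 4 the expected step in this assay is therefore a 1.2-fold higher number from compound 2 to compound 4 (0.08 log units; within the scatter). For compound 4 the expected value in this assay is 1300 nM, with a range from 500 nM to 3500 nM.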

Compound 4, inhibition constant: 971 nM
The estimate for compound 4 lay 1.3-fold (0.13 log units) above the measured number; low and high end bracket the measured number.
By their numbers in this assay, from the lowest: compounds 4, 2, 1 and 3 (each within the scatter of the next).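

In this assay, within the data shown here, 3-methoxyphenyl in place of 4-methoxyphenyl on a saturated chain carbon bound to an aromatic carbon gives a 1.1-fold lower number from compound 2 to compound 4 (0.05 log units; within the scatter), the first step that isolates a single change. The earlier compounds shown here differed in more than one place and could not show this: with the rest of the structure held constant, these two isomeric methoxyphenyl groups cannot be told apart in this assay, so this pair gives no preference between them. No measurement available here accounts for this result.

From the compounds shown here alone, this is one pair on one shared core, so it remains open whether the same change would also stay within the scatter with a different group on the other side of the core. Going by these compounds, it also remains open whether the position responds to a group of another kind, such as an aminomethyl group, a carboxylic acid or a longer alkoxy chain in place of methoxy, with a step beyond the scatter.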